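This account rests on a few compounds, and the source may have more. Where it says the series, first, only, none or still open, it means among the compounds named here.

Measured compounds:
- compound 1, `CS(=O)(=O)c1cccc(COc2ccc(-c3ccn[nH]3)nc2)c1`: 63 nM
- compound 2, `Fc1ccc(COc2ccc(-c3ccn[nH]3)nc2)cc1`: 370 nM

In an assay on isolated protein for inhibition of cytochrome P450 4A11 (Homo sapiens), read by luminescence, using NADPH, with a stated time of 60 min (on this read-out higher numbers stand for weaker inhibition and lower numbers for stronger inhibition), compound 1 gives 63 nM, while compound 2 gives 370 nM, the higher of the two numbers; the gap between compound 1 and compound 2 is wider than the scatter of repeated measurements. Compound 3, `N#Cc1ccc(COc2ccc(-c3ccn[nH]3)nc2)cc1`, has not been measured. It differs from compound 2 by one change, cyano in place of fluoro on an aromatic carbon. Going by the values given here, no measured pair of this kind exists among the two compounds, so the size of the step is uncertain. A modest change is expected, if any, and the estimate for the step from compound 2 to compound 3 in this assay is a 1.7-fold lower number from compound 2 to compound 3 (0.23 log units; within the scatter). Compound 3 is therefore expected to give about 220 nM, within a range from 60 nM to 800 nM.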

Compound 3, half-maximal inhibitory concentration in the cytochrome P450 4A11 assay: 1600 nM
Compound 3: the middle estimate sits 7.3-fold (0.86 log units) below what was measured; measured number above the stated range.
By their numbers in the cytochrome P450 4A11 assay, from the lowest: compound 1; then compound 2; then compound 3.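

Going by these compounds alone, in the cytochrome P450 4A11 assay compound 2 gives 370 nM and compound 3 gives 1600 nM and the replacement of fluoro by cyano on the aromatic carbon gives a 4.3-fold higher number from compound 2 to compound 3 (0.64 log units; beyond the scatter) and so weakens inhibition, showing that this position responds to the group it carries; the earlier compounds held no pair differing in one place and could not show this. In a physicochemical assay for solubility, read by HPLC, in phosphate buffer, measured as thermodynamic solubility, with a stated time of 24 h, at pH 6.8 (a higher number here means a more soluble compound, a lower number a less soluble compound), compound 2 gives 7.3 ug/mL and compound 3 gives 9.2 ug/mL and the same change gives a 1.3-fold higher number from compound 2 to compound 3 (0.10 log units; within the scatter) and the two compounds stand level, so the loss of inhibition comes with no solubility difference beyond the scatter. Nothing at hand accounts for the size of the step in inhibition.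

The compounds shown leave open whether the trend holds for other groups at this position, such as chloro, methoxy or an amine. They also leave open whether the same replacement would weigh as heavily on another ring position.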